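Quinazoline series: anilino substituent and cytotoxicity on HGC-27 cells

The source may hold more compounds than are shown below. What is called first, only, known or untested is meant among the compounds shown, and "the series" means these compounds.

Measured so far, in a functional assay on HGC-27 cells (Homo sapiens) for cytotoxicity, read by MTT assay, with a stated time of 72 h; a lower number here means a stronger inhibitor, a higher number a weaker inhibitor:
- compound 1 `CCCCCCCCNc1nc(SCc2ccc(C(F)(F)F)cc2)nc2ccccc12`: 13400 nM
- compound 2 `CCOc1ccccc1Nc1nc(SCc2ccc(C(F)(F)F)cc2)nc2ccccc12`: > 50000 nM
- compound 3 `Fc1ccc(Nc2nc(SCc3ccc(C(F)(F)F)cc3)nc3ccccc23)cc1`: 19500 nM

All three share one core and differ only in the group on the ring nitrogen. Compound 2 gives > 50000 nM, which is the limit of > 50000 nM in this assay, at which 1 of the 3 values shown sits, rather than a number. Compound 3 sits alongside compound 1: the step of a 1.5-fold higher number from compound 1 to compound 3 (0.16 log units; within the scatter) is within the scatter, so the two cannot be ranked. Against compound 2 the step of an at least 2.5-fold lower number from compound 2 to compound 3 (0.40 log units; beyond the scatter) is beyond the scatter, and an at least 3.7-fold higher number from compound 1 to compound 2 (0.57 log units; beyond the scatter) points the same way.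

Compound 4 `FC(F)(F)c1ccc(CSc2nc(Nc3ccc(C(F)(F)F)cc3)c3ccccc3n2)cc1` is the next step from compound 3: trifluoromethyl in place of fluoro on an aromatic carbon. Within the data shown here, no measured step exchanges one group for another on the same aromatic carbon of that ring; the steps above swap the whole group on the nitrogen. Among the measured compounds shown here, the only step among phenyl-bearing compounds, an at least 2.5-fold lower number from compound 2 to compound 3 (0.40 log units; beyond the scatter), moves an ethoxy from one place to a fluoro at another and is not a guide to this change. With nothing bearing directly on it, the expectation is a step of a 1.0-fold higher number from compound 3 to compound 4 (0.01 log units; within the scatter), that is, none beyond the scatter. Compound 4 is therefore estimated at 20000 nM, with a range from 7000 nM to 55000 nM in this assay.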

Compound 4, half-maximal inhibitory concentration: 7560 nM
The estimate for compound 4 lay 2.6-fold (0.42 log units) above the measured number; low and high end bracket the measured number.
By their numbers in this assay, from the lowest: compounds 4, 1 and 3 (each within the scatter of the next, the first and the last beyond it). At a limit, above all of these: compound 2.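

In this assay, among these compounds, this is the first exchange made at a single aromatic carbon, para to a large group, and it gives a 2.6-fold lower number from compound 3 to compound 4 (0.41 log units; beyond the scatter), so the group at this position changes the read-out by more than the scatter, whereas the earlier steps swapped the whole group on the nitrogen; at the same time, a 1.8-fold lower number from compound 1 to compound 4 (0.25 log units; within the scatter) leaves the 4-(trifluoromethyl)phenyl and octyl groups on the nitrogen unranked. The step of an at least 6.6-fold lower number from compound 2 to compound 4 (0.82 log units; beyond the scatter) gives only a bound on the gap to the 2-ethoxyphenyl group, not its size. Compound 2 stands at a limit of the assay and has no number: the limit of > 50000 nM in this assay, at which 1 of the 4 values shown sits.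

As far as these compounds go, with only fluoro and trifluoromethyl to compare at this position, two groups cannot show a trend, and it remains open whether chloro, methoxy, a nitrile or an amine there would fall with compound 4 or with compound 3. Also open, from the compounds shown here alone, is whether the same exchange would give a similar step on an octyl-free partner carrying a different group on the sulfur in place of the 4-(trifluoromethyl)benzyl group.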